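Solubility notes on amide analogues of a shared core

This account rests on a few compounds, and the source may have more. Where it says the series, first, only, none or still open, it means among the compounds named here.

Measured compounds:
compound 1 `O=C(Nc1ccccc1)c1cnc(NCc2c(F)ccc3c2CCO3)n2cnnc12`, < 1000 nM
compound 2 `Cc1nc(CO)ccc1-c1cnc(NCc2c(F)ccc3c2CCO3)c2cn[nH]c(=O)c12`, 3000 nM
compound 3 `Cc1nc(CN(C)C)ccc1-c1cnc(NCc2c(F)ccc3c2CCO3)c2cn[nH]c(=O)c12`, > 1000000 nM

In a physicochemical assay for solubility, read by LC-MS, in phosphate buffer, with a stated time of 24 h, at pH 7.4 (a higher number here means a more soluble compound, a lower number a less soluble compound), compound 1 gives < 1000 nM, which is a limit of the assay rather than a number, the one described by the limit of < 1000 nM in this assay, at which 1 of the 3 values shown sits. Compound 1 therefore stands at the low edge of what this series shows. Compound 3 gives > 1000000 nM, also a limit, described by the limit of > 1000000 nM in this assay, at which 1 of the 3 values shown sits. Going by the values given here, the one step measured, an at least 330-fold higher number from compound 2 to compound 3 (2.52 log units; beyond the scatter), concerns a different change on a different part of the core and does not bear directly on the change at hand.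

Compound 4 `O=C(Nc1cnc(NCc2c(F)ccc3c2CCO3)n2cnnc12)c1cccnc1` carries ((pyridin-3-yl)carbonyl)amino in place of phenylcarbamoyl on an aromatic carbon. Among the compounds with values here, no measured step covers this change, so the expectation rests on the structural change alone and on the fact that compound 1 sits at a limit. The step of an at least 2.0-fold higher number from compound 1 to compound 4 (0.30 log units; that floor lies within the scatter) is expected to be small to moderate, toward a higher number. For compound 4 the estimate in this assay is 2000 nM, with a range from 500 nM to 8000 nM, and a fair chance that only a limit is again reported.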

Compound 4, solubility: 12000 nM
Beside the measured number, compound 4's estimate is 6.0-fold (0.78 log units) below it, and the stated range ends below it.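

In this assay ((pyridin-3-yl)carbonyl)amino in place of phenylcarbamoyl on this aromatic carbon gives an at least 12-fold higher number from compound 1 to compound 4 (1.07 log units; beyond the scatter) and is the only step shown at this position, beyond the scatter. This change turns the amide around and also brings a hetero atom into the six-membered aromatic ring, so the series now holds a large step at a site that the step between compound 2 and compound 3 did not touch. As far as these compounds go, the step is only a floor and its full size stays unknown, because the value of compound 1 is a limit and not a number: the limit of < 1000 nM in this assay, at which 1 of the 4 values shown sits.

Open, from the compounds shown here alone, is whether the reversed amide or the ring nitrogen carries the step, as neither appears alone in these compounds. Also open, going by these compounds, is how a carboxylic acid or a morpholine on the pyridine ring of compound 4 would read in this assay.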